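A few compounds are considered here, and "the series" means these few. Any claim that something is new, unique, unknown or untested is made for them only; others in the source may bear on it.

The series begins with compound 1 `CC(C)C(/C=C1\OC(=O)NC1=O)c1cc(Cl)c(-c2ccc3cccc(F)c3c2)[nH]c1=O`, which in an assay on membranes from Chem-1 cells for displacement of a labelled ligand from prostaglandin E2 receptor EP3 subtype (Homo sapiens), read by scintillation counting, with a stated time of 2 h (on this read-out higher numbers stand for weaker inhibition and lower numbers for stronger inhibition), gives 380 nM. Compound 2 `O=C1NC(=O)/C(=C/C(c2ccc(-c3ccc4cccc(F)c4c3)[nH]c2=O)C2CC2)O1` gives in this assay a value of 22 nM. Of the two numbers, compound 2 stands lowest, and its nearest neighbour compound 1 sits at a higher number, a gap that lies beyond the scatter, so compound 2 is the more tightly binding of the two measured compounds. Compound 3 `CCC(CC)C(/C=C1\OC(=O)NC1=O)c1ccc(-c2ccc3cccc(F)c3c2)[nH]c1=O` has not yet been measured. It differs from compound 2 by pentan-3-yl in place of cyclopropyl on a saturated chain carbon bound to an aromatic carbon and a double-bonded chain carbon. Among the measured compounds shown here, no pair of measured compounds differing in a single place is available to calibrate this change, so the expectation rests on the general picture: the cyclopropyl bearer is the strongest measured compound, and pentan-3-yl is a larger, open-chain group in the same place. A modest loss is expected, a step from compound 2 to compound 3 of a 2.7-fold higher number from compound 2 to compound 3 (0.44 log units; beyond the scatter), though it could also fall within the scatter. For compound 3 the expected value in this assay is 60 nM, estimated to lie between 15 nM and 250 nM.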

Compound 3, inhibition constant: 13 nM
Compound 3: middle estimate off by 4.6-fold (0.66 log units), on the high side, outside the stated range (below it).
By their numbers in this assay, from the lowest: compounds 3 and 2 (each within the scatter of the next); then compound 1.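

In this assay, pentan-3-yl in place of cyclopropyl on a saturated chain carbon bound to an aromatic carbon and a double-bonded chain carbon gives a 1.7-fold lower number from compound 2 to compound 3 (0.23 log units; within the scatter), so the two groups cannot be told apart on this read-out. Among the compounds shown here, this is the first comparison that changes a single place, and it shows that this position can carry an open-chain group of 5 heavy atoms with no ring in place of a three-membered ring of 3 heavy atoms, with no change beyond the scatter. Nothing measured here explains why the two groups read alike.

As far as these compounds go, it remains open whether the same place would also accept a much smaller group such as methyl, or a group carrying an amine or a carboxylic acid. Compound 1 differs from the other two compounds in more than one place, so the compounds shown leave open which of those differences accounts for its higher number.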